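A few compounds are considered here, and "the series" means these few. Any claim that something is new, unique, unknown or untested is made for them only; others in the source may bear on it.

Measured compounds in a functional assay on BGC-823 cells (Homo sapiens) for antiproliferative activity, read by MTT assay, with a stated time of 48 h; a higher number here means a weaker inhibitor, a lower number a stronger inhibitor:
- compound 1, `Cc1ccc(N2CCN(Cn3nc(-c4ccc5c(c4)OCCO5)oc3=S)CC2)c(C)c1`, gives 28300 nM.
- compound 2, `Fc1ccc(N2CCN(Cn3nc(-c4ccc5c(c4)OCCO5)oc3=S)CC2)cc1`, gives > 50000 nM, which is a limit of the assay rather than a number.

Going by the values given here, compound 2 therefore stands at the limit (the limit of > 50000 nM in this assay, at which 1 of the 2 values shown sits); only the one measured step leads to it, an at least 1.7-fold higher number from compound 1 to compound 2 (0.24 log units; that floor lies within the scatter), and since its floor lies within the scatter it is not known whether compound 2 is genuinely weaker than compound 1 or merely too weak to read.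

Compound 3, `COc1cccc(N2CCN(Cn3nc(-c4ccc5c(c4)OCCO5)oc3=S)CC2)c1`, differs from compound 2 by 3-methoxyphenyl in place of 4-fluorophenyl on an amine nitrogen in a ring. Among the compounds with values here, the only step that bears on this change is the one from compound 1 to compound 2, where a 4-fluorophenyl group also replaced an aryl group on the same ring nitrogen; it gave at most a shift within the scatter and otherwise only a limit. Nothing measured here separates a 3-methoxyphenyl group from the other two aryl groups, so no step beyond the scatter is expected, and a result at the limit remains quite possible.

Compound 3 is expected to give 35000 nM, with a range of 12000 nM to 100000 nM. The step this implies, an at least 1.4-fold lower number from compound 2 to compound 3 (0.15 log units; that floor lies within the scatter), is an expectation only and lies within the scatter.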

Compound 3, half-maximal inhibitory concentration: > 50000 nM
Compound 3: only a limit was reported; the forecaster's own chance of this, stated with the estimate: 45%; middle value at least 1.4-fold (0.15 log units) away from the limit.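

In this assay compound 3 gives > 50000 nM, which is a limit of the assay and not a number, so a 3-methoxyphenyl group on the amine nitrogen in the ring gives no readable value, just as a 4-fluorophenyl group did. Against the one readable number the result is an at least 1.7-fold higher number from compound 1 to compound 3 (0.24 log units; that floor lies within the scatter), so no genuine loss of activity is established, and the step between the two limits cannot be read. The new finding is that a second aryl group at this position ends at the same limit, which leaves the 2,4-dimethylphenyl group of compound 1 as the only one here with a readable number: the limit of > 50000 nM in this assay, at which 2 of the 3 values shown sit.

With so few readable values, the aryl groups shown cannot be ranked, and nothing separates the effect of the group from the limit of the assay. Also open, as far as these compounds go, is whether, set against compound 1 at 28300 nM, a pyridyl ring or a benzyl group on that nitrogen would give a readable number.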